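One inverted stereocentre: from compound 3 to compound 4

The source may hold more compounds than are shown below. What is called first, only, known or untested is meant among the compounds shown, and "the series" means these compounds.

Measured so far in an ADME assay on BJ cells (Homo sapiens) for cytotoxicity, read by CellTiter-Glo, with a stated time of 72 h; a higher number here means that more compound is needed for the effect, a lower number that less compound is needed

Compound 1 `C/C1=C/C2=C[C@H](C)C[C@@]23O[C@]2(CC(C)(C)C[C@@H]2[C@@]1(O)C(F)(F)F)[C@@H](C)C3=O` gives 26000 nM
Compound 2 `CC1=C2CC(C)(C)/C=C/[C@H](O)/C(C)=C\C3=C[C@H](C)C[C@]3(O2)C1=O` gives 10600 nM
Compound 3 `CC(=O)O[C@H]1/C=C/C(C)(C)CC2=C(C)C(=O)[C@]3(C[C@@H](C)C=C3/C=C\1C)O2` gives 26000 nM

Compound 3 at 26000 nM shares the highest of the three numbers with compound 1 (26000 nM) and stands apart from compound 2 (10600 nM). That gap is the measured step of a 2.5-fold higher number from compound 2 to compound 3 (0.39 log units; beyond the scatter) and it comes with acetyl in place of hydrogen on an oxygen on a saturated carbon.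

The next compound is compound 4 `CC(=O)O[C@@H]1/C=C/C(C)(C)CC2=C(C)C(=O)[C@]3(C[C@@H](C)C=C3/C=C\1C)O2` and its relation to compound 3 is simple: the two compounds have the same atoms and bonds and differ only in configuration as drawn: 1 of 5 stereo elements differ; a stereocentre at a saturated ring carbon is drawn S in compound 3 and R in compound 4 and so nothing leaves and nothing enters.

Among the compounds with values here, no measured step here changes configuration alone, so the data give no direct size for this change. The modest step of a 2.5-fold higher number from compound 2 to compound 3 (0.39 log units; beyond the scatter) is the only one available, and it bears on this change only loosely, as it concerns a different kind of change. In this assay no step beyond the usual scatter is therefore expected, and neither direction is favoured. The expected step is a 1.1-fold lower number from compound 3 to compound 4 (0.03 log units; within the scatter) and it remains an estimate. For compound 4 the estimated value is 24000 nM with an expected range from 11000 nM to 45000 nM and the measurement is still to come.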

Compound 4, half-maximal effective concentration: 26000 nM
For compound 4 the middle estimate is 1.1-fold (0.03 log units) below the measured one, within the range that was stated.
By their numbers in this assay, from the lowest: compound 2; then compounds 1, 3 and 4 (each within the scatter of the next).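

Turning the stereocentre at a saturated ring carbon from S to R gives no change at the digits printed from compound 3 to compound 4 (within the scatter) in this assay, so at this position the drawn configuration leaves no mark on the number. Within the data shown here, the earlier compounds could not show this, as their one step, a 2.5-fold higher number from compound 2 to compound 3 (0.39 log units; beyond the scatter), came with acetyl in place of hydrogen on an oxygen on a saturated carbon and left the configuration untouched. The new step can be read as a change of configuration alone, and what allows that reading is a single point: the fact that compounds 3 and 4 differ only in the configuration as drawn

The compounds shown leave open whether this configuration would count for as little with hydrogen on that oxygen, as in compound 2, or with a longer chain such as a benzoyl ester or an ester carrying an amine in place of the acetyl. They also leave open whether the S and R forms stay level in any read-out other than this assay, since this single pair gives no wider rule about the other stereo elements of the shared core.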